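This account rests on a few compounds, and the source may have more. Where it says the series, first, only, none or still open, it means among the compounds named here.

Compound 1, `CC1(C)CCNc2ccc(NC(=S)Nc3ccc([N+](=O)[O-])cc3)cc21`, gives 7100 nM in a functional assay on A2780 cells (Homo sapiens) for inhibition, with a stated time of 72 h; on this read-out higher numbers stand for weaker inhibition and lower numbers for stronger inhibition.
Compound 2, `CC1(C)CCNc2ccc(NC(=S)Nc3ccc(C(F)(F)F)cc3)cc21`, gives 6000 nM in this assay.
Compound 3, `CN1c2ccc(NC(=S)Nc3ccc([N+](=O)[O-])cc3)cc2C(C)(C)C(=O)C1(C)C`, gives 4400 nM in this assay.

The first two compounds share one core and differ only in a single group: trifluoromethyl in place of nitro on an aromatic carbon. This change produced a 1.2-fold lower number from compound 1 to compound 2 (0.07 log units; within the scatter). Compound 3 carries a different core; the difference between the two cores is not broken down here. Its value and those of compound 1 and compound 2 all lie within the usual scatter of one another, so no order among the three is claimed.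

Compound 4, `CN1c2ccc(NC(=S)Nc3ccc(C(F)(F)F)cc3)cc2C(C)(C)C(=O)C1(C)C`, has not yet been measured in this assay. It differs from compound 3 by trifluoromethyl in place of nitro on an aromatic carbon, the same change that separates compound 1 from compound 2, made at a place described in the same words. Its effect on the new core is therefore expected to be close to the earlier one: compound 4 is estimated to show a 1.2-fold lower number from compound 3 to compound 4 (0.08 log units; within the scatter), resting on a 1.2-fold lower number from compound 1 to compound 2 (0.07 log units; within the scatter). For compound 4 the expected value is 3700 nM, with a range from 1800 nM to 7500 nM.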

Compound 4, half-maximal inhibitory concentration: 3900 nM
Compound 4: the middle estimate sits 1.1-fold (0.02 log units) below what was measured, within the range that was stated.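

Trifluoromethyl in place of nitro on the core of compound 3 gives a 1.1-fold lower number from compound 3 to compound 4 (0.05 log units; within the scatter) in this assay. Set beside the earlier step, the change reads the same on both cores, with no difference between the two steps: the same change on two cores in this assay, a 1.2-fold lower number (0.07 log units; within the scatter) from compound 1 to compound 2 and a 1.1-fold lower number (0.05 log units; within the scatter) from compound 3 to compound 4, 1.0-fold (0.02 log units) apart, within the scatter of two such steps. Going by these compounds alone, both steps lie within the scatter, however, so the result shows only that this exchange leaves the read-out without a discernible shift on these two cores; it does not show that an effect of real size carries from one core to the other, since neither step has such an effect to carry.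

The compounds shown leave open whether another group on that aromatic carbon, such as an amine, a carboxylic acid or a nitrile, would move the number beyond the scatter on either core. They also leave open what a longer chain in place of the methyl on the ring nitrogen of compound 3 would do in this assay.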